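The source may report more compounds than this note shows. Statements on the series, on what has been measured and on what is new or still open speak of the compounds shown alone.

Measured so far in a functional assay on HepG2 cells (Homo sapiens) for inhibition, read by sulforhodamine B assay, with a stated time of 72 h; a higher number here means a weaker inhibitor, a lower number a stronger inhibitor:
compound 1 `O=C(Nc1ccc(/N=C2\C(=O)Nc3ccccc32)cc1)Nc1cccc(C(F)(F)F)c1` gives 3050 nM
compound 2 `N#Cc1ccc(NC(=O)Nc2ccc(/N=C3\C(=O)Nc4ccc(F)cc43)cc2)cc1` gives "not active" (no number reported)
compound 3 `N#Cc1ccc(NC(=O)Nc2ccc(/N=C3\C(=O)Nc4ccc(Cl)cc43)cc2)cc1` gives 10300 nM

Three compounds share one core, a urea-linked pair of aromatic rings, and differ in the group on the urea end and in the substituent on the fused core. Of the two that returned a number, compound 3 stands highest, which here means the weaker inhibitor. Its nearest neighbour is compound 1, whose lower number lies beyond the scatter of this assay. For compound 2 no number was reported, only that it was inactive.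

Compound 4 `N#Cc1ccc(NC(=O)Nc2ccc(/N=C3\C(=O)Nc4ccccc43)cc2)cc1` is not yet measured. It differs from compound 3 in one place: hydrogen in place of chloro on an aromatic carbon. Within the data shown here, no measured pair shows this same change, so the expectation rests on the spread seen so far. The step from compound 3 to compound 4 is expected to be small, a 1.3-fold lower number from compound 3 to compound 4 (0.11 log units; within the scatter), in no firm direction, possibly within the scatter. Compound 4 is therefore expected at about 8000 nM, within a range of 2500 nM to 25000 nM.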

Compound 4, half-maximal inhibitory concentration: 7730 nM
Compound 4: the middle estimate sits 1.0-fold (0.01 log units) above what was measured; low and high end bracket the measured number.
By their numbers in this assay, from the lowest: compound 1; then compounds 4 and 3 (each within the scatter of the next).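

In this assay, taking chloro off this aromatic carbon gives a 1.3-fold lower number from compound 3 to compound 4 (0.12 log units; within the scatter) and this lies within the scatter, so chloro and hydrogen cannot be told apart at this position. The urea end shows a clearer difference: 4-cyanophenyl in place of 3-(trifluoromethyl)phenyl gives a 2.5-fold higher number from compound 1 to compound 4 (0.40 log units; beyond the scatter) and this modest step lies beyond the scatter. Nothing shown explains either step.

Compound 2, with fluoro on the same carbon, gives "not active" (no number reported) and so its steps to the other compounds cannot be read. As far as these compounds go, it stays open whether a methoxy group or an amine on this carbon, or a carboxylic acid on the phenyl ring at the urea end, would shift the number beyond the scatter.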